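A few compounds are considered here, and "the series" means these few. Any claim that something is new, unique, unknown or untested is made for them only; others in the source may bear on it.

Measured compounds:
- compound 1, `CC(C)(C)c1ccc(C(=O)N2CCC3(CC2)C(=O)N(CC(=O)NCCO)CN3c2ccccc2)cc1`, gives 1000 nM in an assay on HEK293 cells for displacement of a labelled ligand from NPC1-like intracellular cholesterol transporter 1 (Homo sapiens); a lower number here means a stronger inhibitor, a higher number a weaker inhibitor
- compound 2, `O=C(CN1CN(c2ccccc2)C2(CCN(C(=O)c3ccc(C4CCCCC4)cc3)CC2)C1=O)N1CCC(CO)CC1`, gives 1100 nM in this assay
- compound 3, `O=C(CN1CN(c2ccccc2)C2(CCN(C(=O)c3ccc(C4CCCCC4)cc3)CC2)C1=O)N1CCCCC1`, gives 1100 nM in this assay

Compound 1 has the lowest of the three numbers, but its distance to compound 2 and to compound 3 lies within the scatter of repeated measurements, so no order among the three can be read from these values.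

The step under consideration leads from compound 1 to compound 4, `CC1CCCN(C(=O)CN2CN(c3ccccc3)C3(CCN(C(=O)c4ccc(C(C)(C)C)cc4)CC3)C2=O)C1`. The change is 3-methylpiperidin-1-yl in place of (2-hydroxyethyl)amino on a carbonyl carbon.

Among the compounds with values here, one measured step bears on it. From compound 2 to compound 3 a hydroxymethyl on a saturated ring carbon is replaced by hydrogen, with no change at the digits printed from compound 2 to compound 3 (within the scatter). Compound 3, which already carries an unsubstituted piperidin-1-yl on the corresponding carbonyl carbon, stands within the scatter of compound 1. Within the data shown here, both observations point the same way: taking away the hydroxyl-bearing chain and closing the amide nitrogen into a ring has not moved the number so far, so no step beyond the scatter is expected from compound 1 to compound 4, no change at the digits printed from compound 1 to compound 4 (within the scatter).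

Compound 4 is therefore estimated at 1000 nM in this assay, with a range from 450 nM to 2200 nM.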

Compound 4, half-maximal inhibitory concentration: 12000 nM
Compound 4: middle estimate off by 12-fold (1.08 log units), on the low side, and the stated range ends below it.
By their numbers in this assay, from the lowest: compounds 1, 2 and 3 (each within the scatter of the next); then compound 4.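

In this assay, the step of a 12-fold higher number from compound 1 to compound 4 (1.08 log units; beyond the scatter) shows that, on the core of compound 1, this carbonyl carbon is not indifferent to the group it carries. The earlier step of no change at the digits printed from compound 2 to compound 3 (within the scatter) could not show this, since it changed only a hydroxymethyl on a saturated ring carbon and left the piperidine amide in place, whereas here (2-hydroxyethyl)amino, with its hydrogen-bond donors and acceptor, gives way to 3-methylpiperidin-1-yl, which has none. No measurement shown gives a reason for the large step, so it stands as an observation only.

Compound 3 and compound 4 differ in more than one place, so what the methyl contributes on its own cannot be read, nor whether the loss follows from the ring, the methyl or the combination of either with the tert-butyl-bearing benzoyl part. As far as these compounds go, it also remains open where a morpholin-4-yl or a dimethylamino on this carbonyl carbon of the core of compound 1 would fall in this assay, and whether a simple open-chain amide without a hydroxyl would stay close to compound 1 or close to compound 4.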